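A few compounds are considered here, and "the series" means these few. Any claim that something is new, unique, unknown or untested is made for them only; others in the source may bear on it.

Values so far in an in vitro ADME assay on microsomes from liver (Mus musculus) for pharmacokinetics, read by LC-MS, with a stated time of 10 min, tested at 1 uM; a higher number here means faster removal of the compound, a lower number slower removal

Compound 1 `CN1C[C@H](C(=O)Nc2ccccc2F)[C@@H](c2ccc(/C=C/C(=O)Nc3ccccc3N)cc2)C1` gives 67 mL/min/kg
Compound 2 `Cc1cc(NC(=O)[C@H]2CN(C)C[C@@H]2c2ccc(/C=C/C(=O)Nc3ccccc3N)cc2)ccc1Cl` gives 65 mL/min/kg
Compound 3 `CN1C[C@H](C(=O)Nc2ccc(Cl)cc2F)[C@@H](c2ccc(/C=C/C(=O)Nc3ccccc3N)cc2)C1` gives 43 mL/min/kg

The step of a 1.6-fold lower number from compound 1 to compound 3 (0.19 log units; within the scatter) and the step of a 1.5-fold lower number from compound 2 to compound 3 (0.18 log units; within the scatter) both stay within the scatter, so compound 3 does not stand apart from the other two in this assay on these numbers.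

Compound 4 `Cc1ccc(NC(=O)[C@H]2CN(C)C[C@@H]2c2ccc(/C=C/C(=O)Nc3ccccc3N)cc2)cn1` carries 6-methylpyridin-3-yl in place of 4-chloro-2-fluorophenyl on an amide-type nitrogen, and the rest of the molecule stays the same.

Those two steps bear on this change, as does the step of a 1.0-fold lower number from compound 1 to compound 2 (0.01 log units; within the scatter), since all three alter the group on that same nitrogen. None of them goes beyond the scatter. However, none of the measured compounds has a ring with a hetero atom at this place, so the data do not test that feature directly, and the estimate carries a wide range.

No step beyond the scatter is therefore expected in this assay, and the estimated step is small (a 1.2-fold higher number from compound 3 to compound 4 (0.07 log units; within the scatter)), with its direction unsettled. For compound 4 the estimated clearance is 50 mL/min/kg (expected range 27 mL/min/kg to 85 mL/min/kg).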

Compound 4, clearance: 57 mL/min/kg
Compound 4: middle estimate off by 1.1-fold (0.06 log units), on the low side; the range from low to high includes it.
By their numbers in this assay, from the lowest: compounds 3, 4, 2 and 1 (each within the scatter of the next).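

In this assay, for the compounds shown here, 6-methylpyridin-3-yl is the first ring with a hetero atom on the amide-type nitrogen, and it stays within the scatter of all three compounds with a carbon-only ring there: the steps read a 1.3-fold higher number from compound 3 to compound 4 (0.12 log units; within the scatter), a 1.1-fold lower number from compound 2 to compound 4 (0.06 log units; within the scatter) and a 1.2-fold lower number from compound 1 to compound 4 (0.07 log units; within the scatter). Among these four compounds, then, exchanging a six-membered aromatic ring of carbon only for one with 1 hetero atom, which also brings 1 hydrogen-bond acceptor and leaves out the chlorine and fluorine of 4-chloro-2-fluorophenyl, does not set compound 4 apart, a question the earlier compounds could not address. Nothing available here accounts for how closely these groups agree in this read-out.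

The compounds shown leave open whether a group of another kind on this nitrogen, such as a piperidine, a carboxylic acid or a longer alkyl chain, would produce a step beyond the scatter. As far as these compounds go, how an unsubstituted pyridin-3-yl would compare with compound 4 also remains open, as does the effect of any change to the shared core.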